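A few compounds are considered here, and "the series" means these few. Any claim that something is new, unique, unknown or untested is made for them only; others in the source may bear on it.

Compound 1 `O=C(CC(CC(=O)NC1Cc2ccccc2C1)c1ccc(Cl)cc1)NCCN1CCCCC1` gives 70400 nM in a functional assay on L02 cells (Homo sapiens) for inhibition; a higher number here means a weaker inhibitor, a lower number a stronger inhibitor.
Compound 2 `O=C(CC(CC(=O)NC1Cc2ccccc2C1)c1ccc(Cl)cc1)NCCN1CCCC1` gives 89400 nM in this assay.
Compound 3 `O=C(CC(CC(=O)NC1Cc2ccccc2C1)c1ccccc1)NCCN1CCCC1` reaches only > 100000 nM in this assay, a limit of the assay and not a number.

Of the two numbers, compound 2 holds the highest; its nearest neighbour is compound 1, the step being a 1.3-fold higher number from compound 1 to compound 2 (0.10 log units; within the scatter). Towards compound 3 the step is an at least 1.1-fold higher number from compound 2 to compound 3 (0.04 log units; that floor lies within the scatter), with chloro giving way to hydrogen. Compound 4 `CCN(C(=O)CC(CC(=O)NCCN1CCCC1)c1ccc(Cl)cc1)C1Cc2ccccc2C1` differs from compound 2 by ethyl in place of hydrogen on an amide-type nitrogen. Neither measured step touches an amide-type nitrogen, so neither bears directly on this change; both were within the scatter, and the series sits near the top of the assay's range. The expected step is therefore a 1.0-fold lower number from compound 2 to compound 4 (0.00 log units; within the scatter), nothing beyond the scatter. Compound 4 is expected to give 89000 nM, between 35000 nM and 100000 nM, with a real chance of only a limit.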

Compound 4, half-maximal inhibitory concentration: 54200 nM
Compound 4: the middle estimate sits 1.6-fold (0.22 log units) above what was measured; measured number inside the range.
By their numbers in this assay, from the lowest: compounds 4, 1 and 2 (each within the scatter of the next). At a limit, above all of these: compound 3.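

Ethyl is accepted on the amide-type nitrogen whose other neighbours are a carbonyl carbon and a saturated ring carbon, with a 1.6-fold lower number from compound 2 to compound 4 (0.22 log units; within the scatter). Among the compounds shown here, no earlier step touched this nitrogen, so this is the first sign that the amide hydrogen here can give way to ethyl without a change beyond the scatter. Compound 3 alone remains at a limit, not a number: the limit of > 100000 nM in this assay, at which 1 of the 4 values shown sits.

On these data alone, whether a longer chain on this nitrogen would move the number beyond the scatter stays open. So does the effect of a carboxylic acid or an amine carried there.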